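This account rests on a few compounds, and the source may have more. Where it says the series, first, only, none or still open, it means among the compounds named here.

Going by the values given here, in a functional assay on HT-29 cells (Homo sapiens) for antiproliferative activity, read by MTT assay, with a stated time of 72 h (a lower number here means a stronger inhibitor, a higher number a weaker inhibitor), compound 2 (`C=C(Br)C(=O)Nc1ccc2c(c1)/C(=C/c1ccc[nH]1)C(=O)N2`) gives 800 nM and so stands in the middle of the three numbers so far. Compound 1 (`C=C(Br)C(=O)Nc1ccc2c(c1)/C(=C\c1ccsc1)C(=O)N2`) is lower at 310 nM and compound 3 (`C#CC(=O)Nc1ccc2c(c1)/C(=C/c1ccc[nH]1)C(=O)N2`) is higher at 2300 nM on the same scale.

The next compound to test, compound 4 (`C=C(Br)C(=O)Nc1ccc2c(c1)/C(=C/c1sccc1C)C(=O)N2`), keeps the 1-bromoethenyl group of compound 2 and changes only the group on a double-bonded chain carbon bound to a double-bonded ring carbon (3-methylthiophen-2-yl in place of 1H-pyrrol-2-yl on a double-bonded chain carbon bound to a double-bonded ring carbon). Among the compounds with values here, the single measured step between compounds that differ in one place is a 2.9-fold higher number from compound 2 to compound 3 (0.46 log units; beyond the scatter) and it is modest. That change sits on a carbonyl carbon, so it shows only how large one change has been in this small set, not what this new swap will do. Compound 1 offers a loose hint, since it also has the 1-bromoethenyl group and a sulfur-containing ring at this place, and it gives 310 nM (lower than compound 2). Its ring is not the same group, however, so the hint is weak.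

A small drop in the number is therefore expected in this assay and it may not clear the scatter. Within the data shown here, the expected change is a 1.9-fold lower number from compound 2 to compound 4 (0.28 log units; within the scatter) and no larger step is assumed. The expected value for compound 4 is 420 nM (estimated range 140 nM to 1300 nM).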

Compound 4, half-maximal inhibitory concentration: 1200 nM
The estimate for compound 4 lay 2.9-fold (0.46 log units) below the measured number; the measured number falls inside the stated range.
By their numbers in this assay, from the lowest: compound 1; then compounds 2, 4 and 3 (each within the scatter of the next, the first and the last beyond it).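

Replacing 1H-pyrrol-2-yl with 3-methylthiophen-2-yl on a double-bonded chain carbon bound to a double-bonded ring carbon gives, in this assay, a 1.5-fold higher number from compound 2 to compound 4 (0.18 log units; within the scatter), so this pair of rings cannot be told apart in this assay. The swap removes the hydrogen-bond donor of the pyrrole ring and brings in a sulfur atom and a methyl group, so for this pair, losing that donor leaves no change that can be separated from the scatter, and having a sulfur-containing ring at this place does not in itself give a clearly different number. No supporting information is available to explain this result at the level of the molecules involved.

The incoming group differs from the outgoing one in both its ring atoms and its methyl group, so the effect of each remains unresolved, and a plain thiophen-2-yl group at this place would be needed to separate them. On these data alone, it also remains open how far this place accepts other kinds of group, such as a phenyl ring or a pyrrole ring carrying an amine or a carboxylic acid.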